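Swapping a Chloro for an Amino on a Purine-like Core

The source may report more compounds than this note shows. Statements on the series, on what has been measured and on what is new or still open speak of the compounds shown alone.

Compound 1, with the structure `ClCc1cccc(Cn2cnc3c(Cl)nc(Cl)nc32)c1`, was tested in a functional assay on MOLT-4 cells (Homo sapiens) for cytotoxicity, read by sulforhodamine B assay, with a stated time of 48 h; a higher number here means that more compound is tolerated, a lower number that less compound is tolerated. In this assay compound 1 gives only a limit, > 100000 nM, and not a number; it is the value at the limit of > 100000 nM in this assay, at which 1 of the 3 values shown sits. Two further compounds in which the same core carries the side chain in a different way have been measured as well: compound 2, `ClCc1cccc(Cn2cnc3nc(Cl)nc(Cl)c32)c1`, gives 5010 nM, and compound 3, `ClCc1ccccc1Cn1cnc2nc(Cl)nc(Cl)c21`, gives 7940 nM. The step from compound 1 to compound 4 is not among the measured ones, so its size is open.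

Compound 4, with the structure `Nc1nc(Cl)c2ncn(Cc3cccc(CCl)c3)c2n1`, differs from compound 1 in one place: amino in place of chloro on an aromatic carbon. A chloro leaves and an amino enters, bringing one hydrogen-bond donor and one acceptor. Among the measured compounds shown here, no measured step tells how this change moves cytotoxicity, and compound 1 itself offers only a limit to build on.

The expectation for compound 4 is therefore set near where compound 1 sits, with a wide range to either side: an estimated 100000 nM, between 30000 nM and 300000 nM. This means an expected step of a number no higher from compound 1 to compound 4 (the limit leaves the size open), which is no change beyond the scatter.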

Compound 4, concentration lethal to 50% of the cells: > 100000 nM
Compound 4 gave a limit, no number; the forecaster's own chance of this, stated with the estimate: 55%; the middle value lies on the limit itself.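

In this assay, compound 1 and compound 4 each give only a limit and not a number, so no step between them can be read: the limit of > 100000 nM in this assay, at which 2 of the 4 values shown sit.

The compounds shown leave open how far, and in which direction, amino in place of chloro moves cytotoxicity on the shared core.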